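The source may report more compounds than this note shows. Statements on the series, on what has been measured and on what is new or still open speak of the compounds shown alone.

Measured in a functional assay on CWR22R cells (Homo sapiens) for antiproliferative activity, read by CCK-8 assay, with a stated time of 6 days; on this read-out lower numbers stand for stronger inhibition and higher numbers for weaker inhibition:
- compound 1 `CC(O)c1ccc(C(=O)N[C@@H](C)Cn2ccc(-c3ccc(C#N)c(Cl)c3)n2)cc1`: 9050 nM
- compound 2 `COc1ccc(C(=O)N[C@@H](C)Cn2ccc(-c3ccc(C#N)c(Cl)c3)n2)cc1`: "not determined" (no result reported)
- compound 3 `C[C@@H](Cn1ccc(-c2ccc(C#N)c(Cl)c2)n1)Nc1ccccc1`: > 30000 nM (a limit)

Compound 3 stands at > 30000 nM in this assay, which is a limit of the assay and not a number. Compound 4 `C[C@@H](Cn1ccc(-c2ccc(C#N)c(Cl)c2)n1)Nc1nccc(Cl)n1` carries 4-chloropyrimidin-2-yl in place of phenyl on an amine nitrogen. Among the measured compounds shown here, no measured step bears on this change, so the expectation is loose. For the measured compounds named here, the only number available is compound 1 at 9050 nM, and it sets the scale. A modest move toward stronger inhibition is expected, with the estimated step of an at least 1.8-fold lower number from compound 3 to compound 4 (0.27 log units; that floor lies within the scatter). A further limit result remains quite possible. For compound 4 the estimate is 16000 nM, with an expected range of 5000 nM to 40000 nM.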

Compound 4, half-maximal inhibitory concentration: > 30000 nM
Compound 4 was reported as a limit; the forecaster's own chance of this, stated with the estimate: 45%; at least 1.8-fold (0.27 log units) between middle value and limit.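

Compound 3 and compound 4 both stand at a limit of the assay and not at a number in this assay, so no step can be read between them: the limit of > 30000 nM in this assay, at which 2 of the 4 values shown sit.

The compounds shown leave open how phenyl and 4-chloropyrimidin-2-yl on an amine nitrogen compare.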